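A Hydroxymethyl Group Replaces the Imidazole on the Core

The source may hold more compounds than are shown below. What is called first, only, known or untested is meant among the compounds shown, and "the series" means these compounds.

Compound 1 `CCCCN(c1nc2c(C(=O)O)cccc2o1)[C@H](C)c1ccc(-c2ccccc2-c2nnn[nH]2)cc1` gives 17 nM in a functional assay on CAL1 cells for inhibition of chemerin-like receptor 1 (Homo sapiens), with a stated time of 45 min; a lower number here means a stronger inhibitor, a higher number a weaker inhibitor.
Compound 2 `CCCCN(c1nc2c(NS(C)(=O)=O)cccc2o1)[C@H](C)c1ccc(-c2ccccc2-c2nnn[nH]2)cc1` gives 14 nM in this assay.
Compound 3 `CCCCN(c1nc2c(-c3nccn3C)cccc2o1)[C@H](C)c1ccc(-c2ccccc2-c2nnn[nH]2)cc1` gives 10 nM in this assay.

Compound 3 has the lowest number of the three, but its distance to the others is small: a 1.7-fold lower number from compound 1 to compound 3 (0.23 log units; within the scatter) and a 1.4-fold lower number from compound 2 to compound 3 (0.15 log units; within the scatter), so none of the three can be set apart from the others. Compound 4 `CCCCN(c1nc2c(CO)cccc2o1)[C@H](C)c1ccc(-c2ccccc2-c2nnn[nH]2)cc1` carries a change at the same spot on the core: hydroxymethyl in place of 1-methyl-1H-imidazol-2-yl on an aromatic carbon. Among the compounds with values here, two measured steps touch this spot, and both were within the scatter: a 1.7-fold lower number from compound 1 to compound 3 (0.23 log units; within the scatter) and a 1.4-fold lower number from compound 2 to compound 3 (0.15 log units; within the scatter), and also a 1.2-fold lower number from compound 1 to compound 2 (0.08 log units; within the scatter) between the first two groups. Three quite different groups have sat at this spot with no real change in the numbers, so the hydroxymethyl group is expected to behave alike, with an expected step of a 1.5-fold higher number from compound 3 to compound 4 (0.18 log units; within the scatter) from compound 3 to compound 4 that does not exceed the scatter. Compound 4 is therefore estimated at 15 nM, in the range 6 nM to 40 nM.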

Compound 4, half-maximal inhibitory concentration: 24 nM
For compound 4 the middle estimate is 1.6-fold (0.20 log units) below the measured one; measured number inside the range.
By their numbers in this assay, from the lowest: compounds 3, 2, 1 and 4 (each within the scatter of the next, the first and the last beyond it).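

Within the data shown here, the spot on the core is not wholly indifferent to the group it carries: in this assay the change to hydroxymethyl gives a 2.4-fold higher number from compound 3 to compound 4 (0.38 log units; beyond the scatter), the first step here to pass the scatter, though a modest one. The hydroxymethyl group still cannot be told apart from the other two groups that are not rings at this spot, as shown by a 1.7-fold higher number from compound 2 to compound 4 (0.23 log units; within the scatter) and a 1.4-fold higher number from compound 1 to compound 4 (0.15 log units; within the scatter), so the separation holds only against the 1-methyl-1H-imidazol-2-yl group of compound 3. Nothing available explains this step.

The compounds shown cannot say whether the ring itself matters, or whether the hydroxymethyl group alone sets compound 4 apart. A methoxymethyl or aminomethyl group, or a different five-membered ring such as a pyrazole, at this spot would bear on that question.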